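Same atoms, joined differently: what to expect of compound 4

The source may hold more compounds than are shown below. What is called first, only, known or untested is meant among the compounds shown, and "the series" means these compounds.

Of the compounds shown here, three sharing one core have been measured in a physicochemical assay for lipophilicity, read by HPLC, at pH 7.5; on this read-out lower numbers stand for lower lipophilicity and higher numbers for higher lipophilicity: compound 1 `CC[C@@H](Nc1c(C#N)c(-c2ccc(-c3ccc(F)cc3)cc2)nc2cnccc12)C(N)=O`, compound 2 `CC[C@@H](Nc1c(C#N)c(-c2ccc(Br)cc2)nc2cnccc12)C(N)=O` and compound 3 `CC[C@@H](Nc1c(C#N)c(-c2ccc(-c3ccccc3CO)cc2)nc2cnccc12)C(N)=O`. Compound 1 gives 2.7, compound 2 gives 2.2 and compound 3 gives 2.1. The gap between the last two is small, a number 0.10 log units lower from compound 2 to compound 3 (within the scatter), so they count as level, and compound 1 stands clearly above both.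

The next compound is compound 4 `CC[C@@H](Nc1c(C#N)c(-c2ccc(-c3cccc(OC)c3)cc2)nc2cnccc12)C(N)=O`. It carries 3-methoxyphenyl in place of 2-(hydroxymethyl)phenyl on an aromatic carbon, para to a large group, and so has the same atoms joined differently: 3-methoxyphenyl in place of 2-(hydroxymethyl)phenyl on an aromatic carbon.

The closest guide is the swap of 4-fluorophenyl for 2-(hydroxymethyl)phenyl, which gave a number 0.60 log units lower from compound 1 to compound 3 (beyond the scatter). Compound 4 reverses the second half of that swap, leaving the hydroxymethyl group behind. The swap to bromo is a looser guide of similar size, with a number 0.50 log units lower from compound 1 to compound 2 (beyond the scatter). For the measured compounds named here, no measured compound carries a 3-methoxyphenyl group, so the guidance is indirect.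

A modest rise in this assay is therefore expected, and the estimated step is a number 0.50 log units higher from compound 3 to compound 4 (beyond the scatter). For compound 4 the estimated value is 2.6, with an expected range from 2.3 to 2.9.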

Compound 4, distribution coefficient: 2.7
For compound 4 the middle estimate is 0.10 log units below the measured one; measured number inside the range.
By their numbers in this assay, from the lowest: compounds 3 and 2 (each within the scatter of the next); then compounds 1 and 4 (each within the scatter of the next).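

In this assay, rejoining the same atoms as 3-methoxyphenyl instead of 2-(hydroxymethyl)phenyl gave a number 0.60 log units higher from compound 3 to compound 4 (beyond the scatter), so at this position the read-out depends on how the atoms are arranged, not only on which atoms are present. The 3-methoxyphenyl group also separates from bromo, with a number 0.50 log units higher from compound 2 to compound 4 (beyond the scatter), whereas the comparison with 4-fluorophenyl gives no change at the digits printed from compound 1 to compound 4 (within the scatter), so two differently substituted phenyl groups here sit level with each other. The counts show that the group leaving has a hydrogen-bond donor and the group entering has none, but nothing available explains the step, so neither that difference nor the new placement of the oxygen can be singled out.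

Compound 3 and compound 4 differ both in the oxygen-bearing group and in where it sits on the outer ring, so the compounds shown leave open what each of these two differences contributes on its own. Also open, as far as these compounds go, is how the read-out would respond at this position to a phenyl group carrying an amine or a carboxylic acid.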